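Ethyl for methyl on the benzoyl of a diacylhydrazine

This account rests on a few compounds, and the source may have more. Where it says the series, first, only, none or still open, it means among the compounds named here.

Measured compounds:
compound 1 `CC(C)(C)N(NC(=O)c1ccccc1F)C(=O)c1ccccc1Cl` with 51.3 nM
compound 2 `CC(C)(C)N(NC(=O)c1ccccc1Cl)C(=O)c1ccccc1Cl` with 331 nM
compound 3 `Cc1cccc(C(=O)NN(C(=O)c2ccccc2Cl)C(C)(C)C)c1` with 603 nM

In an assay on cells for agonist activity at ecdysone receptor (Bombyx mori), read by a luciferase reporter, with a stated time of 24 h (on this read-out lower numbers stand for an effect already at smaller amounts and higher numbers for an effect only at larger amounts of compound), compound 3 gives the highest of the three numbers. Its nearest neighbour is compound 2, and the gap a 1.8-fold higher number from compound 2 to compound 3 (0.26 log units; within the scatter) stays within the scatter; the gap to compound 1, a 12-fold higher number from compound 1 to compound 3 (1.07 log units; beyond the scatter), lies beyond it.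

Compound 4 `CCc1ccc(C(=O)NN(C(=O)c2ccccc2Cl)C(C)(C)C)cc1` has not yet been measured. It differs from compound 3 in one place: 4-ethylphenyl in place of 3-methylphenyl on a carbonyl carbon. Two of the measured steps touch the same carbonyl carbon. The step of a 12-fold higher number from compound 1 to compound 3 (1.07 log units; beyond the scatter) was large, and the step of a 1.8-fold higher number from compound 2 to compound 3 (0.26 log units; within the scatter) was within the scatter; both exchange the whole aryl group on that carbonyl, while the step of a 6.5-fold higher number from compound 1 to compound 2 (0.81 log units; beyond the scatter) changed only a halogen. For the measured compounds named here, none of these steps puts a 4-ethylphenyl on the carbonyl carbon, so there is no direct precedent for the change from compound 3 to compound 4. On what the measured compounds show, compound 4 is expected to give about 450 nM in this assay, within a range from 120 nM to 1700 nM. The step expected is a 1.3-fold lower number from compound 3 to compound 4 (0.13 log units; within the scatter), not clearly beyond the scatter in either direction, given how much the aryl swaps among compound 1, compound 2 and compound 3 differed in size.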

Compound 4, half-maximal effective concentration: 5.75 nM
Compound 4: middle estimate off by 78-fold (1.89 log units), on the high side, outside the stated range (below it).
By their numbers in this assay, from the lowest: compound 4; then compound 1; then compounds 2 and 3 (each within the scatter of the next).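

In this assay, the aryl group on this carbonyl carbon proves able to move the number much further than the earlier swaps showed: 4-ethylphenyl in place of 3-methylphenyl gives a 100-fold lower number from compound 3 to compound 4 (2.02 log units; beyond the scatter) and so exceeds every step among the first three compounds. The same group also clearly outdoes both halogenated aryl groups, with a 58-fold lower number from compound 2 to compound 4 (1.76 log units; beyond the scatter) against 2-chlorophenyl and an 8.9-fold lower number from compound 1 to compound 4 (0.95 log units; beyond the scatter) against 2-fluorophenyl, so a halogen on this aryl group is not needed for the lowest number in the set. Compound 3 and compound 4 both carry an alkyl group on the phenyl ring yet lie far apart, so the mere presence of such a group is no guide, and nothing measured here accounts for the gap.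

The step changes both the length of the chain and where it sits on the phenyl ring, and the compounds shown do not separate these two changes. As far as these compounds go, whether a longer chain such as propyl or butyl, or a methoxy group or an amine in place of the ethyl, would keep the number this low also remains open.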